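Sulfonamide aryl substituent series on PC-3 cells

The compounds below may be only part of what the source reports. "The series", "measured", "known", "first", "only" and "open" are said of these compounds alone.

Measured so far:
compound 1 `COc1cc2nc(N3CCN(S(=O)(=O)c4ccc(C(F)(F)F)cc4)CC3)nc(N)c2cc1OC` — 27000 nM
compound 2 `COc1ccc(S(=O)(=O)N2CCN(c3nc(N)c4cc(OC)c(OC)cc4n3)CC2)cc1` — 39000 nM

In a functional assay on PC-3 cells (Homo sapiens) for inhibition (on this read-out higher numbers stand for weaker inhibition and lower numbers for stronger inhibition), compound 1 gives 27000 nM. Compound 2, with methoxy in place of trifluoromethyl on an aromatic carbon, gives 39000 nM in this assay. That step, a 1.4-fold higher number from compound 1 to compound 2 (0.16 log units; within the scatter), lies within the scatter, so the two compounds cannot be ordered; compound 2 simply holds the highest of the two numbers, with compound 1 nearest.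

Compound 3 `COc1cc2nc(N3CCN(S(=O)(=O)c4ccc(C(C)(C)C)cc4)CC3)nc(N)c2cc1OC` is not yet measured. It differs from compound 2 by tert-butyl in place of methoxy on an aromatic carbon. Within the data shown here, the only step that bears on this position is the one from compound 1 to compound 2, exchanging trifluoromethyl for methoxy, and it stayed within the scatter. A further exchange at the same aromatic carbon is therefore expected to give no step beyond the scatter in this assay, in either direction.

Compound 3 is estimated at 30000 nM, with a range of 12000 nM to 80000 nM. This estimate means a step of a 1.3-fold lower number from compound 2 to compound 3 (0.11 log units; within the scatter), expected to stay within the scatter.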

Compound 3, half-maximal inhibitory concentration: 4100 nM
Beside the measured number, compound 3's estimate is 7.3-fold (0.86 log units) above it; the measured number lies below the stated range.
By their numbers in this assay, from the lowest: compound 3; then compounds 1 and 2 (each within the scatter of the next).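

The aromatic carbon para to a large group does respond in this assay: tert-butyl gives a 9.5-fold lower number from compound 2 to compound 3 (0.98 log units; beyond the scatter) and, against trifluoromethyl, a 6.6-fold lower number from compound 1 to compound 3 (0.82 log units; beyond the scatter). The exchange of trifluoromethyl for methoxy, at a 1.4-fold higher number from compound 1 to compound 2 (0.16 log units; within the scatter), had shown no such separation, so that flat first pair did not describe the position as a whole. No measurement at hand accounts for the drop with tert-butyl.

On these data alone, whether the lower number is particular to tert-butyl stays open, since isopropyl, cyclohexyl or a longer alkyl chain at this carbon would be needed to tell. An amine or a carboxylic acid at the same carbon also remains an open case, as does whether tert-butyl keeps this effect when the shared core is changed elsewhere.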